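A Methylsulfanyl Group on the Amide Aryl Ring

The compounds below may be only part of what the source reports. "The series", "measured", "known", "first", "only" and "open" are said of these compounds alone.

Compound 3 `O=C(Nc1ccccc1)c1cccc(/C=C2\CC(=O)N(c3ccccc3)C2=O)c1` belongs to a small set of amides built on a shared core, differing only in the group on the amide nitrogen. In an ADME assay on HCT-116 cells (Homo sapiens) for cytotoxicity, read by MTT assay, with a stated time of 72 h (on this read-out lower numbers stand for stronger inhibition and higher numbers for weaker inhibition), compound 3 gives only a limit, > 100000 nM. Compound 1 `O=C(NCC1CCCCC1)c1cccc(/C=C2\CC(=O)N(c3ccccc3)C2=O)c1` likewise gives only a limit in this assay, > 100000 nM. Compound 2 `COc1ccc(NC(=O)c2cccc(/C=C3\CC(=O)N(c4ccccc4)C3=O)c2)cc1` also gives only a limit in this assay, > 100000 nM. All three values sit at the limit of > 100000 nM in this assay, at which 3 of the 3 values shown sit, so the steps between them, a step that the two limits leave unreadable from compound 1 to compound 2, a step that the two limits leave unreadable from compound 1 to compound 3 and a step that the two limits leave unreadable from compound 2 to compound 3, carry no readable size. Compound 4 `CSc1cccc(NC(=O)c2cccc(/C=C3\CC(=O)N(c4ccccc4)C3=O)c2)c1` differs from compound 3 by methylsulfanyl in place of hydrogen on an aromatic carbon. The nearest measured step, a step that the two limits leave unreadable from compound 2 to compound 3, also alters a substituent on this aromatic ring, yet gives no size to lean on. Among the measured compounds shown here, with no measured step pointing beyond the scatter, compound 4 is expected to stay close to compound 3, with an estimated step of a number no higher from compound 3 to compound 4 (the limit leaves the size open). Compound 4 is therefore estimated at 100000 nM, within 30000 nM to 300000 nM, and most likely reported again as a limit.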

Compound 4, half-maximal inhibitory concentration: 65200 nM
Beside the measured number, compound 4's estimate is 1.5-fold (0.19 log units) above it; low and high end bracket the measured number.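

Methylsulfanyl on this aromatic carbon, meta to a large group, makes compound 4 the only compound shown with a measured number in this assay and not a limit. The change reads as an at least 1.5-fold lower number from compound 3 to compound 4 (0.18 log units; that floor lies within the scatter), and the wider differences in the amide group read as an at least 1.5-fold lower number from compound 2 to compound 4 (0.18 log units; that floor lies within the scatter) and as an at least 1.5-fold lower number from compound 1 to compound 4 (0.18 log units; that floor lies within the scatter), so each gives only a floor and none gives a true size. The other three compounds stay at the assay limit: the limit of > 100000 nM in this assay, at which 3 of the 4 values shown sit.

The compounds shown leave open whether a methylsulfonyl group or a longer chain such as ethylsulfanyl on the same aromatic carbon would also give a measured number. They also leave open whether methylsulfanyl would do so from another place on this ring.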